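Sulfonyl aryl exchange on compound 3

The source may hold more compounds than are shown below. What is called first, only, known or untested is meant among the compounds shown, and "the series" means these compounds.

In a functional assay on LOX IMVI cells (Homo sapiens) for cytotoxicity, read by MTT assay, with a stated time of 24 h (a lower number here means a stronger inhibitor, a higher number a weaker inhibitor), compound 1 `COc1cc(-c2nc(-c3ccccc3)[nH]c2-c2ccnc(NCCCNS(=O)(=O)c3ccc(Cl)cc3)n2)ccc1Cl` gives 60900 nM and compound 2 `O=S(=O)(NCCCNc1nccc(-c2[nH]c(-c3ccccc3)nc2-c2ccc(F)c(O)c2)n1)c1ccc(Cl)cc1` gives 14200 nM while compound 3 `O=S(=O)(NCCCNc1nccc(-c2[nH]c(-c3ccccc3)nc2-c2ccc(Cl)c(O)c2)n1)c1ccc(Cl)cc1` gives 61300 nM on the same read-out. The step of a 1.0-fold higher number from compound 1 to compound 3 (0.00 log units; within the scatter) puts those two level, whereas a 4.3-fold higher number from compound 2 to compound 3 (0.64 log units; beyond the scatter) stands clear of the scatter. Compound 4 `O=S(=O)(NCCCNc1nccc(-c2[nH]c(-c3ccccc3)nc2-c2ccc(Cl)c(O)c2)n1)c1cccc(F)c1` keeps the core of compound 3 and differs by 3-fluorophenyl in place of 4-chlorophenyl on a sulfonyl sulfur in the sulfonyl part, with 3-fluorophenyl in place of 4-chlorophenyl on a sulfonyl sulfur. For the measured compounds named here, no measured pair varies this group, so no step bears on it directly. The nearest guide is a 4.3-fold higher number from compound 2 to compound 3 (0.64 log units; beyond the scatter) as an exchange of fluoro and chloro on an aromatic carbon elsewhere in the molecule. Read backwards, it hints weakly at a lower number. In this assay the expected change is a 1.5-fold lower number from compound 3 to compound 4 (0.19 log units; within the scatter) and no larger shift is assumed. For compound 4 the estimate is 40000 nM with an expected range from 14000 nM to 100000 nM given the missing precedent.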

Compound 4, half-maximal inhibitory concentration: 33600 nM
Estimate against measurement, compound 4: 1.2-fold (0.08 log units) above; the range from low to high includes it.
By their numbers in this assay, from the lowest: compound 2; then compounds 4, 1 and 3 (each within the scatter of the next).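

The sulfonyl sulfur position now has its first measured step: in this assay, 3-fluorophenyl in place of 4-chlorophenyl gives a 1.8-fold lower number from compound 3 to compound 4 (0.26 log units; within the scatter) and leaves the pair level, whereas all earlier steps kept 4-chlorophenyl on the sulfur and varied only the other aryl group. For the compounds shown here, the halogen and its ring position change together here, so this single step cannot separate the two, and its reading covers only this exchange on the core of compound 3. No measurement at hand gives a cause for the result.

Still open, on these data alone, is whether 3-chlorophenyl or 4-fluorophenyl on the sulfonyl sulfur would also stay level with compound 3. Also open, as far as these compounds go, is how this position responds to something further from a halophenyl, such as a pyridine ring or a carboxylic acid on the phenyl ring.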